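The compounds below may be only part of what the source reports. "The series", "measured", "known", "first", "only" and "open" are said of these compounds alone.

Measured so far:
compound 1, `CNc1[nH]c(=O)n(O)c(=O)c1C(=O)NCc1ccccc1`: 51 uL/min
compound 2, `CCNc1[nH]c(=O)n(O)c(=O)c1C(=O)NCc1cccc(Cl)c1F`: 850 uL/min

In an ADME assay on microsomes from liver (Mus musculus) for metabolic stability (on this read-out higher numbers stand for fast clearance and lower numbers for slow clearance), compound 2 holds the higher of the two numbers, and its gap to compound 1 lies beyond the scatter. Compound 3, `CCNc1[nH]c(=O)n(O)c(=O)c1C(=O)NCc1ccc(C)c(F)c1`, has not been measured. It differs from compound 2 in one place: 3-fluoro-4-methylphenyl in place of 3-chloro-2-fluorophenyl on a saturated chain carbon bound to an amide-type nitrogen. For the measured compounds named here, no step between two measured compounds shows what such a change does, so the expected step is set near zero: a 1.2-fold lower number from compound 2 to compound 3 (0.08 log units; within the scatter) is estimated to stay within the scatter. Compound 3 is therefore expected to give 700 uL/min, with a range from 250 uL/min to 1800 uL/min.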

Compound 3, intrinsic clearance in a liver preparation (reported as CLH), per the amount of preparation that the assay uses in the Mus musculus assay: 357 uL/min
Estimate against measurement, compound 3: 2.0-fold (0.29 log units) above; measured number inside the range.
By their numbers in the Mus musculus assay, from the lowest: compound 1; then compound 3; then compound 2.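

For the compounds shown here, replacing 3-chloro-2-fluorophenyl with 3-fluoro-4-methylphenyl on a saturated chain carbon bound to an amide-type nitrogen gives the first comparison here of compounds that differ in one place, and in the Mus musculus assay it brings a 2.4-fold lower number from compound 2 to compound 3 (0.38 log units; beyond the scatter). In a physicochemical assay for solubility (on this read-out lower numbers stand for lower solubility and higher numbers for higher solubility), compound 2 gives 11000 nM and compound 3 gives 81000 nM. This one pair therefore pairs slower clearance with a higher solubility number.

The compounds shown do not separate the parts of this swap, in which the chlorine leaves and the methyl enters. They also cannot say whether a methoxy group or a nitrile on this ring would behave alike.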